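The source may hold more compounds than are shown below. What is called first, only, known or untested is meant among the compounds shown, and "the series" means these compounds.

Compound 3 `FCC(F)COc1ccc2[nH]ccc2c1` gives 2.3 in a physicochemical assay for lipophilicity, read by NMR (on this read-out lower numbers stand for lower lipophilicity and higher numbers for higher lipophilicity), and the three measured numbers all sit within the scatter of one another, with compound 3 at the low end: compound 1 `FCCCOc1ccc2[nH]ccc2c1` gives 2.5 and compound 2 `FC(F)CCOc1ccc2[nH]ccc2c1` gives 2.6. Among the compounds with values here, compound 4 `FC(F)(F)CCOc1ccc2[nH]ccc2c1` has not yet been measured. 2,2,2-trifluoroethyl in place of 1,2-difluoroethyl on a saturated chain carbon bound to an oxygen on an aromatic ring The steps that bear on this are a number 0.30 log units lower from compound 2 to compound 3 (within the scatter) and a number 0.10 log units higher from compound 1 to compound 2 (within the scatter), with a number 0.20 log units lower from compound 1 to compound 3 (within the scatter) as the third. Compound 4 carries a third fluorine on the carbon that already holds two in compound 2, so a number near or slightly above that of compound 2 is expected. For compound 4 the estimate is 2.8, between 2.5 and 3.1, an expected step of a number 0.50 log units higher from compound 3 to compound 4 (beyond the scatter).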

Compound 4, partition coefficient: 2.8
Compound 4: the middle estimate sits on the measured number at the digits printed; measured number inside the range.
By their numbers in this assay, from the lowest: compounds 3, 1, 2 and 4 (each within the scatter of the next, the first and the last beyond it).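

Within the data shown here, replacing 1,2-difluoroethyl with 2,2,2-trifluoroethyl gives the first step beyond the scatter in this set, in this assay (a number 0.50 log units higher from compound 3 to compound 4 (beyond the scatter)). The other two new steps (a number 0.20 log units higher from compound 2 to compound 4 (within the scatter); a number 0.30 log units higher from compound 1 to compound 4 (within the scatter)) stay within the scatter, so only compound 3 and compound 4 can be told apart, and compound 1 and compound 2 cannot be separated from either. No measurement shown explains this step. Still open, as far as these compounds go, is how a longer chain, or a chain ending in an amine, would read on this scale.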